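Halogen swap on the fused ring of compound 2

The source may report more compounds than this note shows. Statements on the series, on what has been measured and on what is new or still open speak of the compounds shown alone.

Compound 1 `COc1ccc(C2=NN(C3=NC(=O)/C(=C4\C(=O)Nc5ccccc54)S3)C(c3ccc(OC)cc3)C2)cc1` gives 100000 nM in a functional assay on cells (Cancer cell lines, Homo sapiens) for cytotoxicity, read by sulforhodamine B assay, with a stated time of 48 h; on this read-out lower numbers stand for stronger inhibition of growth and higher numbers for weaker inhibition of growth. Compound 2 `COc1ccc(C2=NN(C3=NC(=O)/C(=C4\C(=O)Nc5ccc(Br)cc54)S3)C(c3ccc(OC)cc3)C2)cc1` gives 200 nM in this assay, the lowest of the two numbers in hand. Among the measured compounds shown here, the only measured step, a 500-fold lower number from compound 1 to compound 2 (2.70 log units; beyond the scatter), arose from bromo in place of hydrogen on an aromatic carbon. On these data alone, compound 3 `COc1ccc(C2=NN(C3=NC(=O)/C(=C4\C(=O)Nc5ccc(Cl)cc54)S3)C(c3ccc(OC)cc3)C2)cc1` is untested; it carries chloro in place of bromo on an aromatic carbon. For the measured compounds named here, no measured pair sets chloro against bromo, but the single step shows how far the number fell when a halogen entered at this carbon, and chloro is expected to retain most of that. The expected step is a 1.5-fold higher number from compound 2 to compound 3 (0.18 log units; within the scatter) in this assay. Compound 3 is expected to give 300 nM, within 100 nM to 1500 nM.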

Compound 3, concentration for 50% growth inhibition: 210 nM
Estimate against measurement, compound 3: 1.4-fold (0.15 log units) above; the range from low to high includes it.
By their numbers in this assay, from the lowest: compounds 2 and 3 (each within the scatter of the next); then compound 1.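

Chloro in place of bromo gives a 1.1-fold higher number from compound 2 to compound 3 (0.02 log units; within the scatter) in this assay and leaves the two halogens indistinguishable at this carbon. Chloro in place of hydrogen gives a 480-fold lower number from compound 1 to compound 3 (2.68 log units; beyond the scatter) as well, so the large fall first seen with bromo is not unique to bromo among these compounds. Nothing available explains either result. Still open, on these data alone, is whether fluoro at this carbon behaves like chloro and bromo, and whether a non-halogen group, such as an amine or a carboxylic acid, retains the low number.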